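The compounds below may be only part of what the source reports. "The series", "measured", "known", "first", "only" and "open" are said of these compounds alone.

Measured so far:
- compound 1 `C#CCSc1nc(N/N=C/c2ccc(N(C)C)cc2)c2nnn(Cc3ccccc3)c2n1`: only a limit of the assay, > 64000 nM
- compound 2 `CCCSc1nc(N/N=C/c2ccccc2Cl)c2nnn(Cc3ccccc3)c2n1`: 13800 nM
- compound 3 `CCCSc1nc(N/N=C(\C)c2ccccc2O)c2nnn(Cc3ccc(F)cc3)c2n1`: only a limit of the assay, > 64000 nM

Among the measured compounds shown here, in a functional assay on MCF7 cells (Homo sapiens) for antiproliferative activity, read by MTT assay, with a stated time of 72 h (on this read-out lower numbers stand for stronger inhibition and higher numbers for weaker inhibition), compound 2 gives the only number among the three; the other two sit at the limit of > 64000 nM in this assay, at which 2 of the 3 values shown sit. For the measured compounds named here, no pair of measured compounds differs in a single place, so no measured step bears directly on the change to compound 4 `CCCSc1nc(N/N=C/c2ccc([N+](=O)[O-])cc2)c2nnn(Cc3ccccc3)c2n1`. That change is 4-nitrophenyl in place of 2-chlorophenyl on a carbon with a double bond to nitrogen. With nothing to set the direction, the step from compound 2 to compound 4 is expected to stay within the usual scatter, a 1.3-fold higher number from compound 2 to compound 4 (0.12 log units; within the scatter), with a real chance that this assay again reports only a limit. Compound 4 is estimated at 18000 nM in this assay, between 4500 nM and 64000 nM.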

Compound 4, half-maximal inhibitory concentration: 11000 nM
Compound 4: middle estimate off by 1.6-fold (0.21 log units), on the high side, within the range that was stated.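

In this assay, 4-nitrophenyl in place of 2-chlorophenyl on a carbon with a double bond to nitrogen gives a 1.3-fold lower number from compound 2 to compound 4 (0.10 log units; within the scatter). This single-place step shows that the two groups cannot be told apart at this position with the rest of the molecule unchanged, and both give a measured number. Compound 1 and compound 3 remain limits of the assay: the limit of > 64000 nM in this assay, at which 2 of the 4 values shown sit.

Still open, as far as these compounds go, is whether any group here, such as a pyridine ring or a carboxylic acid on the phenyl ring, moves the number beyond the scatter. Among the compounds shown here, no step isolates the chain on sulfur, so a longer chain there remains an open question.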